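Replacing the benzyl(ethyl)amino group of a steryl-sulfatase inhibitor

The compounds below may be only part of what the source reports. "The series", "measured", "known", "first", "only" and "open" are said of these compounds alone.

Measured compounds:
- compound 1: `CCN(Cc1cccnc1)c1ccc(C(=O)N2CCc3ccc(OS(N)(=O)=O)cc3C2)cc1`, 85.2%
- compound 2: `CCN(Cc1ccccc1)c1ccc(C(=O)N2CCc3ccc(OS(N)(=O)=O)cc3C2)cc1`, 83.6%

Of the compounds shown here, two have been measured in an assay on HEK293 cells for inhibition of Steryl-sulfatase (Homo sapiens), tested at 1 uM; on this read-out lower numbers stand for a weaker effect and higher numbers for a stronger effect at the one concentration tested. Compound 1 gives 85.2% in this assay. Compound 2 gives 83.6%. Among the compounds with values here, the only step between them, phenyl in place of pyridin-3-yl on a saturated chain carbon bound to a nitrogen on an aromatic ring, is a number 1.6 percentage points lower from compound 1 to compound 2 (within the scatter), so the two values cannot be told apart. Compound 2 stands as the lower of two numbers, with compound 1 within the scatter of it.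

Compound 3, `CN(CCCN1CCCCC1)c1ccc(C(=O)N2CCc3ccc(OS(N)(=O)=O)cc3C2)cc1`, has not yet been measured. It differs from compound 2 by methyl(3-(piperidin-1-yl)propyl)amino in place of benzyl(ethyl)amino on an aromatic carbon. Within the data shown here, no measured step touches this part of the molecule in a comparable way: the one step known, from compound 1 to compound 2, swaps only the aromatic ring on the chain and stays within the scatter. The shared core with its sulfamate is kept in compound 3. Compound 3 is therefore expected to remain an inhibitor, but with a wider range of uncertainty, and its value is estimated at 74%, between 50% and 92%. This means an expected step of a number 9.6 percentage points lower from compound 2 to compound 3 (within the scatter), which may or may not exceed the scatter.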

Compound 3, a percentage reported as inhibition, at one concentration (the size of the read-out at that concentration, not a potency): 40.7%
For compound 3 the middle estimate is 33.3 percentage points above the measured one; the whole stated range lies above it.
By their numbers in this assay, from the lowest: compound 3; then compounds 2 and 1 (each within the scatter of the next).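

The position on an aromatic carbon, para to a large group, proves far less tolerant than the earlier pair suggested: in this assay, methyl(3-(piperidin-1-yl)propyl)amino in place of benzyl(ethyl)amino gives a number 42.9 percentage points lower from compound 2 to compound 3 (beyond the scatter), and in place of ethyl((pyridin-3-yl)methyl)amino it gives a number 44.5 percentage points lower from compound 1 to compound 3 (beyond the scatter). The earlier exchange of one aromatic ring for another on the chain gave only a number 1.6 percentage points lower from compound 1 to compound 2 (within the scatter), so it showed that the group could vary in that one respect, whereas the larger exchange, in which the aromatic ring leaves and a six-membered non-aromatic ring with a hetero atom enters, shows that the read-out does depend on this substituent. Nothing measured here accounts for the size of this loss.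

The compounds shown leave open which part of the exchange carries the loss, since the ring, the chain and the small group on the nitrogen all change at once. On these data alone, how this assay would read with a morpholine ring at the end of the propyl chain, or with a benzyl group kept and methyl in place of ethyl, also remains open.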